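Morpholin-4-yl to 4-Chlorophenyl on an Amide Nitrogen

A few compounds are considered here, and "the series" means these few. Any claim that something is new, unique, unknown or untested is made for them only; others in the source may bear on it.

Compound 1 `COCOc1cc(/C=C/C(=O)OCC(=O)Nc2ccc(Cl)cc2)ccc1OCc1ccccc1`, compound 2 `COCOc1cc(/C=C/C(=O)OCC(=O)NN2CCOCC2)ccc1OCc1ccccc1` and compound 3 `O=C(COC(=O)/C=C/c1ccc(O)c(O)c1)NN1CCOCC1` were each tested in a functional assay on BEL-7404 cells (Homo sapiens) for cytotoxicity, read by MTT assay, with a stated time of 72 h; a higher number here means a weaker inhibitor, a lower number a stronger inhibitor. In this assay compound 1 reaches only the limit > 200000 nM. Compound 2 likewise gives only the limit > 200000 nM. Compound 3 too stops at the limit > 200000 nM. The change from compound 2 to compound 1 is 4-chlorophenyl in place of morpholin-4-yl on an amide-type nitrogen, and the step that the two limits leave unreadable from compound 2 to compound 1 cannot be read because of the limit of > 200000 nM in this assay, at which 3 of the 3 values shown sit. Compound 4 `O=C(COC(=O)/C=C/c1ccc(O)c(O)c1)Nc1ccc(Cl)cc1` carries the same change on the core of compound 3, (4-chlorophenyl in place of morpholin-4-yl on an amide-type nitrogen), while the difference between the cores of compound 3 and compound 2 is not broken down here. The expected step from compound 3 to compound 4 is a step that the limit leaves unreadable from compound 3 to compound 4, set near zero. Because a step that the two limits leave unreadable from compound 2 to compound 1 is unreadable at the limit of > 200000 nM in this assay, at which 3 of the 3 values shown sit, compound 4 is estimated at 250000 nM, between 120000 nM and 500000 nM, most likely again reported only as a limit.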

Compound 4, half-maximal inhibitory concentration: > 200000 nM
Compound 4 ended at the assay's limit; the forecaster's own chance of this, stated with the estimate: 85%; the middle value is on the limit's open side.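

No step can be read from compound 3 to compound 4, because both stop at the assay's limit: the limit of > 200000 nM in this assay, at which 4 of the 4 values shown sit. The compounds shown leave open whether 4-chlorophenyl in place of morpholin-4-yl changes cytotoxicity on either core.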